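The source may hold more compounds than are shown below. What is called first, only, known or untested is meant among the compounds shown, and "the series" means these compounds.

Compounds measured so far in an assay on isolated protein for binding affinity to somatostatin receptor type 4 (Homo sapiens), read by radioligand binding; on this read-out higher numbers stand for weaker inhibition and lower numbers for stronger inhibition:

Compound 1 `NCCCCCOC[C@H]1O[C@@H](OCCc2c[nH]c3ccccc23)[C@H](OCc2ccccc2)[C@@H](OCc2ccccc2)[C@@H]1OCc1ccccn1`: compound 1 gives 890 nM
Compound 2 `NCCCCCOC[C@H]1O[C@@H](OCCc2c[nH]c3ccccc23)[C@H](OCc2ccccc2)[C@@H](OCc2ccccc2)[C@@H]1OCc1cnccn1`: compound 2 gives 260 nM
Compound 3 `NCCCCCOC[C@H]1O[C@@H](OCCc2c[nH]c3ccccc23)[C@H](OCc2ccccc2)[C@@H](OCc2ccccc2)[C@@H]1OCc1ccc(Cl)nc1`: compound 3 gives 1200 nM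

All three share one core and differ only in the aromatic ring carried on a saturated chain carbon bound to an oxygen on a saturated carbon. Compound 2, with the pyrazin-2-yl ring, has the lowest number of the three in this assay: compound 1 sits a 3.4-fold lower number from compound 1 to compound 2 (0.53 log units; beyond the scatter) away, and compound 3 is further still, with a 4.6-fold higher number from compound 2 to compound 3 (0.66 log units; beyond the scatter).

Compound 4 `NCCCCCOC[C@H]1O[C@@H](OCCc2c[nH]c3ccccc23)[C@H](OCc2ccccc2)[C@@H](OCc2ccccc2)[C@@H]1OCc1ccc(F)nc1` has not yet been measured. It differs from compound 2 in one place: 6-fluoropyridin-3-yl in place of pyrazin-2-yl on a saturated chain carbon bound to an oxygen on a saturated carbon.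

Among the measured compounds shown here, the step that bears most directly on this change is the one from compound 2 to compound 3, where a 6-chloropyridin-3-yl ring replaced the same pyrazin-2-yl ring and gave a 4.6-fold higher number from compound 2 to compound 3 (0.66 log units; beyond the scatter). Compound 4 carries a 6-fluoropyridin-3-yl ring, the same ring pattern with fluorine in place of chlorine, so a step of a similar size and in the same direction is expected in this assay. Compound 1 and compound 3 show that the two other rings tried here both gave higher numbers than compound 2.

Compound 4 is therefore expected to give about 900 nM in this assay, most likely between 350 nM and 2500 nM, which would mean an expected step of a 3.5-fold higher number from compound 2 to compound 4 (0.54 log units; beyond the scatter).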

Compound 4, inhibition constant: 680 nM
For compound 4 the middle estimate is 1.3-fold (0.12 log units) above the measured one; the measured number falls inside the stated range.
By their numbers in this assay, from the lowest: compound 2; then compounds 4, 1 and 3 (each within the scatter of the next).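

The third ring on the pyridine pattern also falls short of the pyrazin-2-yl ring in this assay: 6-fluoropyridin-3-yl in place of pyrazin-2-yl gives a 2.6-fold higher number from compound 2 to compound 4 (0.42 log units; beyond the scatter) and leaves compound 2 as the strongest binder of the four, with its steps to the other three all printed as beyond the scatter. Fluoro in place of chloro on an aromatic carbon gives a 1.8-fold lower number from compound 3 to compound 4 (0.25 log units; within the scatter) and so, within this pair, the choice of halogen makes no clear difference to the read-out. The step to the fluorinated ring from the unsubstituted one, a 1.3-fold lower number from compound 1 to compound 4 (0.12 log units; within the scatter), is also too small to separate 6-fluoropyridin-3-yl from pyridin-2-yl, so among these rings only the pyrazin-2-yl ring stands apart.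

Going by these compounds, it remains open how a plain phenyl ring, a pyrimidin-5-yl ring, or a pyridin-3-yl ring carrying a methoxy group or no group at all in place of the halogen would compare with these four. Nothing measured alongside these numbers accounts for why the pyrazin-2-yl ring gives the lowest number.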